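The source may hold more compounds than are shown below. What is called first, only, known or untested is meant among the compounds shown, and "the series" means these compounds.

Three compounds share one core and differ only in the amine at the end of a three-carbon chain. Compound 1 `COc1cc2c(Nc3ccc(C#N)cc3)ncnc2cc1OCCCN(C)C` carries a dimethylamino group, and in a functional assay on MCF7 cells (Homo sapiens) for antiproliferative activity, read by MTT assay, with a stated time of 72 h (a lower number here means a stronger inhibitor, a higher number a weaker inhibitor), compound 1 gives 45000 nM. Compound 2 `COc1cc2c(Nc3ccc(C#N)cc3)ncnc2cc1OCCCN(C)Cc1ccccc1` bears a benzyl(methyl)amino group instead. In this assay compound 2 reaches only the limit of the measurement, > 100000 nM. Compound 3 `COc1cc2c(Nc3ccc(C#N)cc3)ncnc2cc1OCCCN1CCC(O)CC1` carries a 4-hydroxypiperidin-1-yl group. In this assay compound 3 likewise stops at the limit, > 100000 nM. Compound 3 thus has no number of its own, only a boundary, as described by the limit of > 100000 nM in this assay, at which 2 of the 3 values shown sit. The nearest measured steps are an at least 2.2-fold higher number from compound 1 to compound 3 (0.34 log units; beyond the scatter) and a step that the two limits leave unreadable from compound 2 to compound 3. Compound 4 `CCOC(=O)C1CCN(CCCOc2cc3ncnc(Nc4ccc(C#N)cc4)c3cc2OC)CC1` alters the ring substituent: ethoxycarbonyl in place of hydroxy on a saturated ring carbon. For the measured compounds named here, no measured step touches the hydroxy-bearing ring carbon, and the two steps leading to compound 3 end at a boundary. The expected step is therefore a number no higher from compound 3 to compound 4 (the limit leaves the size open), with no change beyond the scatter foreseen. Compound 4 is estimated at 100000 nM, within a range from 30000 nM to 300000 nM, and is expected most likely to return only a limit again.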

Compound 4, half-maximal inhibitory concentration: 34900 nM
For compound 4 the middle estimate is 2.9-fold (0.46 log units) above the measured one; the range from low to high includes it.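

On the saturated ring carbon three ring bonds from the ring nitrogen, ethoxycarbonyl in place of hydroxy brings a measurable reading in this assay, with an at least 2.8-fold lower number from compound 3 to compound 4 (0.45 log units; beyond the scatter), so the group at this ring position can change the result. The new reading also separates from the benzyl(methyl)amino end group, with an at least 2.8-fold lower number from compound 2 to compound 4 (0.45 log units; beyond the scatter), yet it cannot be told apart from the dimethylamino end group, with a 1.3-fold lower number from compound 1 to compound 4 (0.11 log units; within the scatter). The two larger steps are minimum sizes only, because each starts from a compound with no number of its own: the limit of > 100000 nM in this assay, at which 2 of the 4 values shown sit.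

The compounds shown do not tell which part of ethoxycarbonyl goes with the lower number; a carboxylic acid or a primary amide on the same ring carbon would help separate the carbonyl from the ethyl part. From the compounds shown here alone, the true size of the step away from hydroxy also stays open.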